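The source may report more compounds than this note shows. Statements on the series, on what has been measured and on what is new or still open speak of the compounds shown alone.

Values in a functional assay on RAW264.7 cells (Mus musculus) for inhibition, with stated times of 2 h and 24 h; on this read-out higher numbers stand for weaker inhibition and lower numbers for stronger inhibition:

- Compound 1 `COc1ccc(CSC2c3cc(OC)cc(OC)c3[C@@H](c3ccc(OC)cc3)[C@@H]2c2cc(OC)cc(OC)c2)cc1`: 12500 nM
- Compound 2 `COc1ccc([C@@H]2c3c(OC)cc(OC)cc3C(SCc3ccccc3)[C@H]2c2cc(OC)cc(OC)c2)cc1`: > 200000 nM (a limit)
- Compound 3 `COc1ccc(C(O)C2c3cc(OC)cc(OC)c3[C@@H](c3ccc(OC)cc3)[C@@H]2c2cc(OC)cc(OC)c2)cc1`: > 200000 nM (a limit)

Compound 3 stands at a limit and not at a number, > 200000 nM. Compound 4 `COc1ccc([C@@H]2c3c(OC)cc(OC)cc3C(C(O)c3ccccc3)[C@H]2c2cc(OC)cc(OC)c2)cc1` carries hydrogen in place of methoxy on an aromatic carbon, para to a large group (hydrogen in place of methoxy on an aromatic carbon). The same swap has one measured precedent, an at least 16-fold higher number from compound 1 to compound 2 (1.20 log units; beyond the scatter), which is large and beyond the scatter. The comparison a step that the two limits leave unreadable from compound 2 to compound 3 adds nothing. The precedent points towards weaker inhibition, yet any further rise would stay hidden because of the limit of > 200000 nM in this assay, at which 2 of the 3 values shown sit. In this assay the expected step is therefore not a readable one: a step that the limit leaves unreadable from compound 3 to compound 4. For compound 4 the estimated value is 300000 nM, with an expected range of 100000 nM to 800000 nM.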

Compound 4, half-maximal inhibitory concentration: > 200000 nM
Compound 4: no number, only a limit; the forecaster's own chance of this, stated with the estimate: 90%; the middle value is on the limit's open side.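

In this assay compound 4 gives > 200000 nM as a limit, not a number. Swapping methoxy for hydrogen on this hydroxy-bearing series therefore shows no size of its own, and the steps among compounds 2, 3 and 4 cannot be read: the limit of > 200000 nM in this assay, at which 3 of the 4 values shown sit. Among the compounds shown here, the one readable comparison is an at least 16-fold higher number from compound 1 to compound 4 (1.20 log units; beyond the scatter) and it shows that this alcohol, with or without the methoxy, does not reach the number held by the sulfur-linked compound 1.

Still open, on these data alone, is whether an amine or a carboxylic acid at this ring carbon would bring back a readable value. Also open, as far as these compounds go, is how far the methoxy matters once a value can be read on the alcohol series.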